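This account rests on a few compounds, and the source may have more. Where it says the series, first, only, none or still open, it means among the compounds named here.

Working notes on the series: the shared amide core carries a nitrile-bearing aryl on the nitrogen side and a hydroxy group on the acid side, and the substituent on the acid-side ring is varied. Compound 1 `Cc1ccc(C(=O)Nc2ccc(C#N)cc2)c(O)c1` gives 2560 nM in a functional assay on KG-1 cells (Homo sapiens) for cytotoxicity, read by luminescence and CellTiter-Glo, with a stated time of 3 days; a higher number here means a weaker inhibitor, a lower number a stronger inhibitor. Compound 2 `N#Cc1ccc(NC(=O)c2ccc(-c3cccnc3)cc2O)cc1` gives 7940 nM in this assay, the highest of the three numbers in hand; compound 3 `N#Cc1ccc(NC(=O)c2ccc3cccnc3c2O)cc1`, with its fused ring, gives 2320 nM, a lower number than compound 2, while compound 1 also sits lower than compound 2.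

Among the compounds with values here, the one single-point step available is a 3.1-fold higher number from compound 1 to compound 2 (0.49 log units; beyond the scatter), so the pyridin-3-yl group at that position is the feature that pushes the number up. Compound 4 `N#Cc1ccc(NC(=O)c2ccc(C(F)(F)F)cc2O)cc1` is not yet measured; it differs from compound 2 as follows: trifluoromethyl in place of pyridin-3-yl on an aromatic carbon. Within the data shown here, the only step that bears on this change is the one from compound 1 to compound 2, which ran in the opposite direction when the same pyridin-3-yl was installed, so removing it for a small group without a ring is expected to bring the number back down, roughly toward compound 1.

Compound 4 is therefore expected to give 3000 nM in this assay, within 1200 nM to 8000 nM, which is expected to be a step of a 2.6-fold lower number from compound 2 to compound 4 (0.42 log units; beyond the scatter).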

Compound 4, half-maximal inhibitory concentration: 1440 nM
The estimate for compound 4 lay 2.1-fold (0.32 log units) above the measured number; the measured number falls inside the stated range.
By their numbers in this assay, from the lowest: compounds 4, 3 and 1 (each within the scatter of the next); then compound 2.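

In this assay the step of a 5.5-fold lower number from compound 2 to compound 4 (0.74 log units; beyond the scatter) shows that a ring is not required at this position, the aromatic carbon meta to a hydroxy group and para to a large group: trifluoromethyl, which has no ring, gives a result well clear of that for pyridin-3-yl. The step of a 1.8-fold lower number from compound 1 to compound 4 (0.25 log units; within the scatter) adds that trifluoromethyl and methyl cannot be told apart here, so the two groups without a ring read alike and, of the three substituents compared at this position, only pyridin-3-yl stands apart beyond the scatter from both others. Nothing measured for these compounds offers an explanation for either step.

Open, going by these compounds, is whether a plain phenyl ring at this position would read like pyridin-3-yl, which would separate the contribution of the ring from that of its nitrogen. Also open, on these data alone, are how an amine or a carboxylic acid would read at the same carbon, and whether a longer chain would stay with methyl and trifluoromethyl or move toward pyridin-3-yl.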